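Replacing the Nitro Group of Compound 1 with Amino

This account rests on a few compounds, and the source may have more. Where it says the series, first, only, none or still open, it means among the compounds named here.

In an ADME assay on HepG2 cells (Homo sapiens) for cytotoxicity, read by MTT assay, with a stated time of 48 h (on this read-out lower numbers stand for higher toxicity in this test and higher numbers for lower toxicity in this test), compound 1 `CC(=O)N1C(=O)/C(=C(\Nc2ccc(CN3CCCCC3)cc2)c2ccccc2)c2cc([N+](=O)[O-])ccc21` gives only a limit of > 6 uM. Compound 2 `CCS(=O)(=O)Nc1ccc2c(c1)/C(=C(/NC1CCN(C)CC1)c1ccccc1)C(=O)N2` likewise gives only a limit of > 10 uM. Compound 3 `O=C1Nc2ccccc2/C1=C(/Nc1ccc(CN2CCCCC2)cc1)c1ccccc1` also gives only a limit of > 6 uM. Since none of the three values is a number, compound 1 cannot be ranked against the others; it sits at the limit of > 6 uM in this assay, at which 2 of the 3 values shown sit, while the limit of > 10 uM in this assay, at which 1 of the 3 values shown sits, holds the remaining value. Compound 4 `CC(=O)N1C(=O)/C(=C(\Nc2ccc(CN3CCCCC3)cc2)c2ccccc2)c2cc(N)ccc21` differs from compound 1 by amino in place of nitro on an aromatic carbon. Among the measured compounds shown here, no measured pair in this set carries the same change, so no measured step guides the expectation. Compound 4 is therefore expected to show no step beyond the scatter, estimated as a step that the limit leaves unreadable from compound 1 to compound 4. Compound 4 is expected to give about 8 uM, within 4 uM to 20 uM, most likely again reported as a limit.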

Compound 4, half-maximal toxic concentration: 1.81 uM
For compound 4 the middle estimate is 4.4-fold (0.65 log units) above the measured one, and the stated range ends above it.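

this assay shows that this aromatic carbon matters for the read-out: amino in place of nitro gives an at least 3.3-fold lower number from compound 1 to compound 4 (0.52 log units; beyond the scatter). That step is a minimum, and its full size cannot be read. Compound 4 is the only compound shown with a measured number, while the others give only limits, compound 1 among them: the limit of > 6 uM in this assay, at which 2 of the 4 values shown sit.

On these data alone, whether the lower number is tied to amino itself or would follow the loss of nitro with any other group remains open. A methoxy or dimethylamino group on the same carbon would separate these two readings.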